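The source may report more compounds than this note shows. Statements on the series, on what has been measured and on what is new or still open speak of the compounds shown alone.

Compound 1 `Cc1cc(=O)oc2cc(OCC(=O)c3ccc(C(F)(F)F)cc3)ccc12`: > 100000 nM
Compound 2 `COc1ccc(C(=O)COc2ccc3c(C(F)(F)F)cc(=O)oc3c2)cc1`: "not active" (no number reported)
Compound 3 `N#Cc1ccc(C(=O)COc2ccc3c(C(F)(F)F)cc(=O)oc3c2)cc1`: "not active" (no number reported)

All three compounds were tested in a functional assay on CWR22R cells (Homo sapiens) for antiproliferative activity, with a stated time of 96 h; on this read-out higher numbers stand for weaker inhibition and lower numbers for stronger inhibition. The entry for compound 1, > 100000 nM, is a limit of the assay and not a number. The entry for compound 2 reads "not active" (no number reported). The entry for compound 3 reads "not active" (no number reported), so compound 3 has no single number, and neither of the other two entries offers one for comparison.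

Compound 4 `O=C(COc1ccc2c(C(F)(F)F)cc(=O)oc2c1)c1ccc(C(F)(F)F)cc1` has not yet been measured. The step trifluoromethyl in place of cyano on an aromatic carbon puts trifluoromethyl in place of cyano on an aromatic carbon, para to a large group. Going by the values given here, no measured pair shows the size of such a swap, so no step beyond the scatter is expected in this assay. Compound 1 carries trifluoromethyl at that same place, and its entry is the limit > 100000 nM. Compound 4 is therefore expected to remain essentially inactive, quite possibly reported only as a limit. For compound 4 the estimated value is 100000 nM, with an expected range of 20000 nM to 200000 nM.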

Compound 4, half-maximal inhibitory concentration: "not active" (no number reported)
Compound 4 has no reported number here, so the estimate cannot be set against anything.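

Compound 3 and compound 4 both stand as not active, without a number, in this assay, so no step can be read for trifluoromethyl in place of cyano. The compounds shown leave open whether any of them has a measurable potency, and the only entry of another kind is: the limit of > 100000 nM in this assay, at which 1 of the 4 values shown sits.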